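Swapping a sulfonyl link for a urea on the shared core

This account rests on a few compounds, and the source may have more. Where it says the series, first, only, none or still open, it means among the compounds named here.

Measured so far:
- Compound 1 `COc1ccc(C(=O)N(C)c2ccc3[nH]c(-c4n[nH]c5ccccc45)cc3n2)cc1`: 14600 nM
- Compound 2 `CN(C(=O)c1ccc([N+](=O)[O-])cc1)c1ccc2[nH]c(-c3n[nH]c4ccccc34)cc2n1`: 34500 nM
- Compound 3 `CN(c1ccc2[nH]c(-c3n[nH]c4ccccc34)cc2n1)S(=O)(=O)c1ccc(Cl)cc1`: 18200 nM

In a functional assay on A549 cells (Homo sapiens) for antiproliferative activity, read by MTT assay, with a stated time of 72 h (on this read-out lower numbers stand for stronger inhibition and higher numbers for weaker inhibition), compound 1 gives 14600 nM. The same assay gives for compound 2 34500 nM and for compound 3 18200 nM. Compound 3 thus stands second highest of the three numbers; its step to compound 1 is within the scatter, and its gap to compound 2 is within the scatter as well, so no order among them can be read.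

Compound 4 `CN(C(=O)Nc1ccccc1)c1ccc2[nH]c(-c3n[nH]c4ccccc34)cc2n1` is not yet measured. It differs from compound 3 in one place: phenylcarbamoyl in place of (4-chlorophenyl)sulfonyl on a nitrogen on an aromatic ring.

Two measured steps are of some use. The swap of the group on that same ring nitrogen gave a 1.2-fold higher number from compound 1 to compound 3 (0.10 log units; within the scatter), so exchanging one link for another there has so far moved the number little. The change at the far end of the aromatic ring gave a 2.4-fold higher number from compound 1 to compound 2 (0.37 log units; beyond the scatter), a modest step. Neither step involves a urea, so the evidence is indirect. On that basis the step of a 1.1-fold lower number from compound 3 to compound 4 (0.06 log units; within the scatter) is expected to stay within the scatter, with no clear direction. For compound 4 the estimate is 16000 nM, with a range from 6000 nM to 45000 nM.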

Compound 4, half-maximal inhibitory concentration: 1430 nM
The estimate for compound 4 lay 11-fold (1.05 log units) above the measured number; the measured number lies below the stated range.
By their numbers in this assay, from the lowest: compound 4; then compounds 1, 3 and 2 (each within the scatter of the next, the first and the last beyond it).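

In this assay, the change on this ring nitrogen gives a 13-fold lower number from compound 3 to compound 4 (1.10 log units; beyond the scatter), so this place does respond strongly to what it carries, which the small step of a 1.2-fold higher number from compound 1 to compound 3 (0.10 log units; within the scatter) had not revealed. On the carbonyl carbon, anilino gives a 10-fold lower number from compound 1 to compound 4 (1.01 log units; beyond the scatter) when it replaces 4-methoxyphenyl and a 24-fold lower number from compound 2 to compound 4 (1.38 log units; beyond the scatter) when it replaces 4-nitrophenyl, both large steps, whereas exchanging the methoxy for a nitro on the aromatic ring gave only the modest 2.4-fold higher number from compound 1 to compound 2 (0.37 log units; beyond the scatter). The entering phenylcarbamoyl group counts one hydrogen-bond donor where the groups it replaces count none, but this is only a difference in structure, and no measurement shown here explains the gain.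

With only one urea among the compounds shown, it remains open whether the gain depends on the hydrogen on the anilino nitrogen, which an N-methylanilino group would test, or on the phenyl ring, which a cyclohexylamino group would test. On these data alone, it is also open whether a chlorine or methoxy on the anilino ring would keep the number of compound 4 at 1430 nM or move it further.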